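This account rests on a few compounds, and the source may have more. Where it says the series, first, only, none or still open, it means among the compounds named here.

In a functional assay on A-375 cells (Homo sapiens) for inhibition, read by CCK-8 assay, with a stated time of 72 h, tested at 2 uM (a lower number here means less inhibition of growth, a higher number more inhibition of growth at the concentration tested), compound 1 `CCc1ccc(SCc2ccc(C(=O)Nc3ccccc3N)cc2)cc1` gives 19.6%, and compound 2 `Cc1ccc(SCc2ccc(C(=O)Nc3ccccc3N)cc2)cc1` gives 17.5%. Going by the values given here, the only measured step so far is a number 2.1 percentage points lower from compound 1 to compound 2 (within the scatter), so on these two numbers compound 2 cannot be told apart from compound 1.

The next compound makes a larger structural change. Compound 3 `Nc1ccccc1NC(=O)c1ccc(CSCCc2ccccc2)cc1` keeps the shared core but differs from compound 2 as follows: phenethyl in place of 4-methylphenyl on a sulfur. In words, phenethyl stands in place of 4-methylphenyl on a sulfur whose other neighbour is a saturated chain carbon.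

Among the compounds with values here, the one measured step offers limited guidance. It exchanged only hydrogen for methyl on a saturated chain carbon, whereas here the whole group on the sulfur is replaced. Within the data shown here, that step, a number 2.1 percentage points lower from compound 1 to compound 2 (within the scatter), stayed small, but no measured pair tests a change of this kind, so the data favour no direction. The expected result is therefore no shift beyond the scatter, held with caution: the estimate is a number 3.5 percentage points higher from compound 2 to compound 3 (within the scatter). For compound 3 the estimated value is 21%, with an expected range of 8% to 38%.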

Compound 3, percent growth inhibition at one concentration: 21.8%
The estimate for compound 3 lay 0.8 percentage points below the measured number; measured number inside the range.
By their numbers in this assay, from the lowest: compounds 2, 1 and 3 (each within the scatter of the next).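

The earlier pair changed only a small tail on the ring attached to the sulfur, whereas compound 3 replaces the entire group on that sulfur. In this assay, that larger exchange gives a number 4.3 percentage points higher from compound 2 to compound 3 (within the scatter), and measured against the ethyl-bearing compound it gives a number 2.2 percentage points higher from compound 1 to compound 3 (within the scatter). So the sulfur can carry either 4-methylphenyl, 4-ethylphenyl or phenethyl without a shift that can be told from the scatter, and no reason for this can be given from the information available.

All three groups on the sulfur contain a six-membered aromatic ring of carbon only, so these compounds leave open what happens when that ring is absent, as with a plain hexyl chain, or when the group carries an amine or a carboxylic acid. They also leave open whether any change at this sulfur can move growth inhibition beyond the scatter, since the three compounds shown cannot be told apart at the single concentration tested.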